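The compounds below may be only part of what the source reports. "The series", "measured", "known", "first", "only" and "open" are said of these compounds alone.

Of the compounds shown here, three of a shared core have been tested in an assay on HEK293 cells for inhibition of transient receptor potential cation channel subfamily V member 1 (Homo sapiens); a lower number here means a stronger inhibitor, a higher number a weaker inhibitor. Compound 1 `CCCCCCCCC(=O)NCc1ccc(O)c(OC)c1I` gives 3380 nM. Compound 2 `CCCCCCCCC(=O)NCc1cc(OC)c(O)cc1Cl` gives 50.3 nM. Compound 3 `CCCCCCCCC(=O)NCc1cc(Br)c(O)c(OC)c1` gives 252 nM. Compound 3 therefore sits second highest of the three numbers: its value lies between those of compound 2 and compound 1, and both gaps are beyond the usual scatter of this assay, so compound 3 is a weaker inhibitor than compound 2 and a stronger one than compound 1. No pair among these three differs in only one place, so no single change can be read off from them.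

Compound 4 `CCCCCCCCC(=O)NCc1cc(CC)c(O)c(OC)c1` differs from compound 3 in one place: ethyl in place of bromo on an aromatic carbon. Nothing measured here tells how this particular exchange moves the number. With no guide, the expected step of a 1.6-fold higher number from compound 3 to compound 4 (0.20 log units; within the scatter) is small, if anything a slight rise, and may well stay within the scatter. Compound 4 is expected to give about 400 nM, with a plausible range from 120 nM to 1300 nM.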

Compound 4, half-maximal inhibitory concentration: 355 nM
Beside the measured number, compound 4's estimate is 1.1-fold (0.05 log units) above it, within the range that was stated.
By their numbers in this assay, from the lowest: compound 2; then compounds 3 and 4 (each within the scatter of the next); then compound 1.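

Within the data shown here, compounds 3 and 4 are the first pair here that differ in only one place, so they give the first direct reading of this position. In this assay, putting ethyl in place of bromo on the aromatic carbon ortho to a hydroxy group gives a 1.4-fold higher number from compound 3 to compound 4 (0.15 log units; within the scatter), so the two compounds cannot be told apart, and at this position the single bromine atom and the two carbons of ethyl read alike. Nothing measured here bears on why these two groups give such similar numbers.

A propyl chain, an amine or a carboxylic acid at this same place could still shift the number, and this pair cannot show whether it would. Nor does one pair tell whether the same exchange would read alike on other aromatic carbons of the shared core.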